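From Nitro to Chloro on an Aromatic Ring

The source may report more compounds than this note shows. Statements on the series, on what has been measured and on what is new or still open speak of the compounds shown alone.

In a functional assay on NRK-49F cells (Rattus norvegicus) for cytotoxicity, read by MTT assay, with a stated time of 24 h (a higher number here means a weaker inhibitor, a lower number a stronger inhibitor), compound 1 `COc1cc(/C=C(\C#N)C(=O)N/N=C(\C)c2c(O)c3ccc(O)cc3oc2=O)ccc1O` gives 55400 nM and compound 2 `C/C(=N\NC(=O)/C(C#N)=C/c1ccccc1[N+](=O)[O-])c1c(O)c2ccc(O)cc2oc1=O` gives 68600 nM. These two numbers lie within the usual scatter of each other, so compound 2 cannot be told apart from compound 1 here. Compound 3 `C/C(=N\NC(=O)/C(C#N)=C/c1ccccc1Cl)c1c(O)c2ccc(O)cc2oc1=O` differs from compound 2 in one place: chloro in place of nitro on an aromatic carbon. In short, compound 3 carries a chloro where compound 2 carries a nitro. Among the compounds with values here, no measured step makes this exact swap, so the evidence is indirect. Within the data shown here, the only measured step replaces the whole 4-hydroxy-3-methoxyphenyl with 2-nitrophenyl, and a 1.2-fold higher number from compound 1 to compound 2 (0.09 log units; within the scatter) stays within the scatter. A smaller change is therefore expected to give no step beyond the scatter in this assay. The expected step is a 1.1-fold lower number from compound 2 to compound 3 (0.06 log units; within the scatter). For compound 3 the estimated value is 60000 nM, with an expected range of 28000 nM to 125000 nM.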

Compound 3, half-maximal inhibitory concentration: 55900 nM
Compound 3: middle estimate off by 1.1-fold (0.03 log units), on the high side; measured number inside the range.
By their numbers in this assay, from the lowest: compounds 1, 3 and 2 (each within the scatter of the next).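

Chloro in place of nitro on the aromatic carbon ortho to a large group gives a 1.2-fold lower number from compound 2 to compound 3 (0.09 log units; within the scatter) in this assay, so the nitro with its hydrogen-bond acceptors and the chloro with none cannot be told apart at this position. Replacing the whole 4-hydroxy-3-methoxyphenyl with 2-chlorophenyl gives a 1.0-fold higher number from compound 1 to compound 3 (0.00 log units; within the scatter), so the two phenyl groups also cannot be told apart, and none of the three aryl groups shown separates from the others in this assay. No measurement available here offers an explanation for these results.

As far as these compounds go, whether an amine or a carboxylic acid at this place on the ring would give a step beyond the scatter remains open. The same question stands for a longer chain there.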